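A few compounds are considered here, and "the series" means these few. Any claim that something is new, unique, unknown or untested is made for them only; others in the source may bear on it.

Compound 1 `COc1cccc(-c2csc(NC(=O)c3ccco3)n2)c1`, compound 2 `COc1ccc(-c2csc(NC(=O)c3ccc([N+](=O)[O-])o3)n2)cc1` and compound 3 `O=C(Nc1nc(-c2cccc(Cl)c2)cs1)c1ccc([N+](=O)[O-])o1` share one core, and all three have been tested in an ADME assay on Vero cells (Chlorocebus sabaeus) for cytotoxicity, read by MTT assay, with a stated time of 72 h; on this read-out lower numbers stand for stronger inhibition and higher numbers for weaker inhibition. In this assay compound 1 gives only a limit, > 90000 nM. Compound 2 gives 63000 nM, and compound 3 gives 43700 nM. Among the two numbers obtained, compound 3 has the lowest, yet the step of a 1.4-fold lower number from compound 2 to compound 3 (0.16 log units; within the scatter) shows that compound 2 and compound 3 cannot be told apart. Compound 4 `O=C(Nc1nc(-c2cccc(NC(=O)C3CC3)c2)cs1)c1ccc([N+](=O)[O-])o1` has not yet been measured. It differs from compound 3 in one place: (cyclopropylcarbonyl)amino in place of chloro on an aromatic carbon. Among the compounds with values here, the only measured step changes a group on the same six-membered aromatic ring, and it stayed within the scatter, so nothing here suggests that swapping one group for another at this place moves the number far. No measurement bears directly on a (cyclopropylcarbonyl)amino group. Compound 4 is therefore expected to stay near compound 3, with an estimated step of a 1.1-fold higher number from compound 3 to compound 4 (0.06 log units; within the scatter). The estimate for compound 4 in this assay is 50000 nM, within a range from 20000 nM to 90000 nM.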

Compound 4, half-maximal inhibitory concentration: 35700 nM
Estimate against measurement, compound 4: 1.4-fold (0.15 log units) above, and the stated range covers the measured number.
By their numbers in this assay, from the lowest: compounds 4, 3 and 2 (each within the scatter of the next). At a limit, above all of these: compound 1.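

In this assay, this change is far larger than a swap of one small group for another: (cyclopropylcarbonyl)amino, with 6 heavy atoms, a three-membered ring, 1 hydrogen-bond donor and 1 hydrogen-bond acceptor, replaces chloro, with 1 heavy atom, yet the result is a 1.2-fold lower number from compound 3 to compound 4 (0.09 log units; within the scatter). The earlier compounds shown here could not show that this place on the six-membered aromatic ring accepts so much added size without a readable shift in this number. Compound 1 still offers no step to read, as its value is only a limit: the limit of > 90000 nM in this assay, at which 1 of the 4 values shown sits.

Going by these compounds, whether an amine or a carboxylic acid at this place would leave the number just as unmoved stays open, as does a longer chain in place of the cyclopropyl ring. No pair shown differs only in the nitro group, so its share in these numbers also stays open.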